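The source may report more compounds than this note shows. Statements on the series, on what has been measured and on what is new or still open speak of the compounds shown alone.

Notes on the series. Compound 1 `CCCCCCOc1cc(NC(=O)c2ccc(Br)cc2)ccc1N(C)S(C)(=O)=O` and compound 2 `CCCCCCOc1cc(NC(=O)c2ccc(OC)cc2)ccc1N(C)S(C)(=O)=O` share one core; compound 3 `Cc1ccc(C)c(COc2cc(NC(=O)c3ccc(Br)cc3)ccc2N(C)S(=O)(=O)C(F)(F)F)c1` and compound 4 `COc1ccc(C(=O)Nc2ccc(N(C)S(=O)(=O)C(F)(F)F)c(OCc3cc(C)ccc3C)c2)cc1` share another. How the two cores differ is not broken down here. In a functional assay on SK-BR-3 cells (Homo sapiens) for antiproliferative activity, read by MTT assay, with a stated time of 48 h (a higher number here means a weaker inhibitor, a lower number a stronger inhibitor), compound 1 gives 39900 nM, and compound 2 gives 20000 nM. The change between them, (methoxy in place of bromo on an aromatic carbon), made a step of a 2.0-fold lower number from compound 1 to compound 2 (0.30 log units; within the scatter). In this assay compound 3 gives 36400 nM; its number lies close to that of compound 1 and also to that of compound 2, so no order among the three is read from these values. Compound 4 carries the same change on the core of compound 3: methoxy in place of bromo on an aromatic carbon. Because the same change gave a 2.0-fold lower number from compound 1 to compound 2 (0.30 log units; within the scatter), compound 4 is expected to show a step of a 1.8-fold lower number from compound 3 to compound 4 (0.26 log units; within the scatter) in this assay, an expectation resting on that single measured pair alone. Compound 4 is accordingly estimated at 20000 nM in this assay, with a likely range from 10000 nM to 40000 nM.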

Compound 4, half-maximal inhibitory concentration: 5320 nM
Compound 4: the middle estimate sits 3.8-fold (0.58 log units) above what was measured; measured number below the stated range.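

In this assay, methoxy in place of bromo on an aromatic carbon made a step of a 6.8-fold lower number from compound 3 to compound 4 (0.84 log units; beyond the scatter), and this step does not match the one seen on the core of compound 1: the same change on two cores in this assay, a 2.0-fold lower number (0.30 log units; within the scatter) from compound 1 to compound 2 and a 6.8-fold lower number (0.84 log units; beyond the scatter) from compound 3 to compound 4, 3.4-fold (0.54 log units) apart, beyond the scatter of two such steps

The size of the step therefore does not carry from one core to the other in this series, and only on the core of compound 3 does the change stand clear of the scatter. These two pairs do not show which feature of the cores sets the size of the step, nor do they give a rule for any further core, and the measurements give no cause for the gap.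

Open, on these data alone, is whether a nitrile, a fluoro group or an amine, set where bromo stands, would give steps of equal or unequal size on the two cores. Also open, as far as these compounds go, is which single structural difference between the core of compound 1 and the core of compound 3 goes with the larger step.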